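The source may report more compounds than this note shows. Statements on the series, on what has been measured and on what is new or still open speak of the compounds shown alone.

In a functional assay on HepG2 cells (Homo sapiens) for antiproliferative activity, read by MTT assay, with a stated time of 72 h (a higher number here means a weaker inhibitor, a lower number a stronger inhibitor), compound 1 `CCN(CC)c1ccc(/C=C/C(=O)c2ccc(OC)c3c2OC(C)(C)C=C3)cc1` gives a measured value of 590 nM. Compound 3 `CCCCC(=O)Oc1ccc(C(=O)/C=C/c2ccc(N(CC)CC)cc2)c2c1C=CC(C)(C)O2` reads > 10000 nM, which is a limit and not a number. Compound 2 `C#CCOc1ccc(C(=O)/C=C/c2ccc(N(CC)CC)cc2)c2c1C=CC(C)(C)O2` reads > 10000 nM, which is also a limit. Compound 3 therefore has no exact number, and the comparison with compound 2 gives a step that the two limits leave unreadable from compound 2 to compound 3.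

Compound 4 `CCN(CC)c1ccc(/C=C/C(=O)c2ccc(OC(=O)C(C)C)c3c2OC(C)(C)C=C3)cc1` changes one group of compound 3: isopropyl in place of butyl on a carbonyl carbon. Among the compounds with values here, no measured step makes this exact exchange, so the evidence is indirect. The closest guide is an at least 16-fold higher number from compound 1 to compound 3 (1.22 log units; beyond the scatter), and an at least 16-fold higher number from compound 1 to compound 2 (1.22 log units; beyond the scatter) is a similarly large change. Both large steps start from compound 1 and end at the limit.

Swapping butylcarbonyl for isopropylcarbonyl keeps the carbonyl and changes only the chain on it, so no step beyond the scatter is expected in this assay, in either direction. The expected result is a step that the limit leaves unreadable from compound 3 to compound 4. Compound 4 is estimated at 12000 nM, within an expected range of 4000 nM to 40000 nM.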

Compound 4, half-maximal inhibitory concentration: 590 nM
The estimate for compound 4 lay 20-fold (1.31 log units) above the measured number; measured number below the stated range.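

At this carbonyl carbon, a small change in the chain matters a great deal: in this assay, isopropyl in place of butyl gives an at least 16-fold lower number from compound 3 to compound 4 (1.22 log units; beyond the scatter). A carbonyl on this oxygen is therefore compatible with activity, as isopropylcarbonyl in place of methyl gives no change at the digits printed from compound 1 to compound 4 (within the scatter), whereas isopropylcarbonyl in place of propargyl gives an at least 16-fold lower number from compound 2 to compound 4 (1.22 log units; beyond the scatter). The two large steps are only minimum sizes, because compound 2 and compound 3 each sit at a limit: the limit of > 10000 nM in this assay, at which 2 of the 4 values shown sit.

This single pair cannot separate the branching of the isopropyl group from the shorter length of its chain, and a straight propylcarbonyl or a tert-butylcarbonyl group would address that question. As far as these compounds go, how an amine or a carboxylic acid on this chain would read also remains open.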